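Swapping the Isopropyl Group on Oxygen for 2,4-Difluorophenyl

The source may report more compounds than this note shows. Statements on the series, on what has been measured and on what is new or still open speak of the compounds shown alone.

- compound 1 `CC(C)Oc1ccc(C(C)(C)O)cc1-c1cn(C)c(=O)c2[nH]c(C(=O)NCc3ccc(C(=O)Nc4ccccc4N)cc3)cc12`: 40 nM
- compound 2 `CC(C)Oc1ccc(C(C)(C)O)cc1-c1cn(C)c(=O)c2[nH]c(C(=O)NCc3ccc(C(=O)NO)cc3)cc12`: 350 nM
- compound 3 `Cn1cc(-c2cc(C(C)(C)O)ccc2Oc2ccc(F)cc2F)c2cc(C(=O)NCc3ccc(C(=O)Nc4ccccc4N)cc3)[nH]c2c1=O`: not yet measured

In a functional assay on MV4-11 cells (Homo sapiens) for antiproliferative activity, read by CCK-8 assay, with a stated time of 72 h (a higher number here means a weaker inhibitor, a lower number a stronger inhibitor), compound 1 gives 40 nM, the lower of the two numbers and so the stronger inhibitor of the pair. Its nearest neighbour on the scale is compound 2, at 350 nM.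

The next structure, compound 3, keeps the rest of compound 1 and carries 2,4-difluorophenyl in place of isopropyl on an oxygen on an aromatic ring.

Going by the values given here, only one measured step is available, an 8.8-fold higher number from compound 1 to compound 2 (0.94 log units; beyond the scatter). It is beyond the scatter, but it concerns a different place, hydroxy in place of 2-aminophenyl on an amide-type nitrogen. It shows that this assay can separate members of this series, yet it gives no direct measure of a change on this oxygen. Among the compounds with values here, no measured pair tests that change, so no clear step is expected beyond the scatter, and the uncertainty remains wide in both directions.

The expected step is a 1.3-fold lower number from compound 1 to compound 3 (0.12 log units; within the scatter). For compound 3 the estimated value is 30 nM, with an expected range from 8 nM to 120 nM.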

Compound 3, half-maximal inhibitory concentration: 90 nM
The estimate for compound 3 lay 3.0-fold (0.48 log units) below the measured number, and the stated range covers the measured number.
By their numbers in this assay, from the lowest: compound 1; then compound 3; then compound 2.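

The oxygen on the aromatic ring now has a measured change of its own: in this assay, moving from isopropoxy to 2,4-difluorophenoxy gives a 2.3-fold higher number from compound 1 to compound 3 (0.35 log units; beyond the scatter). The step is modest but beyond the scatter, so this position does register the exchange, and the direction is against compound 3. Even so, the position tolerates the change of a small branched group for 2,4-difluorophenyl, a group with an aromatic ring of carbon, since compound 3 still gives 90 nM and keeps a clear antiproliferative effect on these cells, while nothing shown here bears on why the number rises.

What the compounds shown leave open is whether the step belongs to the aromatic ring itself or to its two fluorine atoms, a question that a plain phenoxy group on this oxygen would address, while a methoxy group would show how the number moves with a smaller group than isopropyl. From the compounds shown here alone, it is also open whether the same exchange would shift the number to the same extent in compound 2, which carries hydroxy in place of 2-aminophenyl on the amide-type nitrogen.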